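A Second Methoxy Group on the Benzoyl Ring

The source may hold more compounds than are shown below. What is called first, only, known or untested is meant among the compounds shown, and "the series" means these compounds.

Three compounds have been measured in a functional assay on HL-60 cells (Homo sapiens) for cytotoxicity, read by MTT assay, with a stated time of 24 h; a higher number here means a weaker inhibitor, a lower number a stronger inhibitor:

Compound 1 `COC(=O)/C(=C\c1ccc(O)cc1)Sc1ccnc2cc(Cl)ccc12`: 4310 nM
Compound 2 `COC(=O)/C(=C\c1ccc(OC(=O)c2ccc(OC)cc2)cc1)Sc1ccnc2cc(Cl)ccc12`: 9090 nM
Compound 3 `COC(=O)/C(=C\c1ccc(OC(=O)c2ccccc2OC)cc1)Sc1ccnc2cc(Cl)ccc12`: 44500 nM

Compound 3 stands highest of the three numbers, with a 4.9-fold higher number from compound 2 to compound 3 (0.69 log units; beyond the scatter) and a 10-fold higher number from compound 1 to compound 3 (1.01 log units; beyond the scatter). Compound 4 `COC(=O)/C(=C\c1ccc(OC(=O)c2ccc(OC)cc2OC)cc1)Sc1ccnc2cc(Cl)ccc12` differs from compound 3 by methoxy in place of hydrogen on an aromatic carbon. Among the compounds with values here, no measured step adds a methoxy group to a ring already carrying one; the nearest comparisons are a 4.9-fold higher number from compound 2 to compound 3 (0.69 log units; beyond the scatter), in which the methoxy group changed position on the same ring, and the two single additions a 2.1-fold higher number from compound 1 to compound 2 (0.32 log units; beyond the scatter) and a 10-fold higher number from compound 1 to compound 3 (1.01 log units; beyond the scatter). Compound 4 holds both arrangements at once, so a modest step downward toward the number of compound 2 is expected, a 2.0-fold lower number from compound 3 to compound 4 (0.31 log units; beyond the scatter). Compound 4 is estimated at 22000 nM, within the range 7000 nM to 70000 nM.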

Compound 4, half-maximal inhibitory concentration: 7640 nM
The estimate for compound 4 lay 2.9-fold (0.46 log units) above the measured number; the range from low to high includes it.
By their numbers in this assay, from the lowest: compounds 1, 4 and 2 (each within the scatter of the next, the first and the last beyond it); then compound 3.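

In this assay, the second methoxy group, meta to the first and para to a large group, gives a 5.8-fold lower number from compound 3 to compound 4 (0.77 log units; beyond the scatter) and so removes most of the loss carried by 2-methoxyphenyl alone. The 2,4-dimethoxyphenyl compound cannot be told apart from its two neighbours, with a 1.2-fold lower number from compound 2 to compound 4 (0.08 log units; within the scatter) and a 1.8-fold higher number from compound 1 to compound 4 (0.25 log units; within the scatter) both inside the usual scatter. Nothing available explains this recovery. The compounds shown leave open whether ethoxy, fluorine or an amine at this position would act as methoxy does.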